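Side-chain amine swap on compound 2: expectation for compound 4

This account rests on a few compounds, and the source may have more. Where it says the series, first, only, none or still open, it means among the compounds named here.

Measured compounds in a functional assay on K562 cells (Homo sapiens) for inhibition, read by MTT assay and WST assay, with a stated time of 72 h, tested at 10 uM; on this read-out lower numbers stand for less inhibition of growth and higher numbers for more inhibition of growth at the one concentration tested:
- compound 1 `CCN1CCN(c2cc(Nc3ccc4sc(C(=O)Nc5c(C)cccc5Cl)cc4c3)nc(C)n2)CC1`: 33.9%
- compound 2 `COc1cc2c(Nc3ccc4sc(C(=O)Nc5c(C)cccc5Cl)cc4c3)ncnc2cc1OCCCN1CCN(C)CC1`: 51.2%
- compound 3 `Cc1nc(Nc2ccc3sc(C(=O)Nc4c(C)cccc4Cl)cc3c2)cc(N2CCC(C)CC2)n1`: 20.5%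

Compound 2 gives the highest of the three numbers in this assay: compound 1 is lower by a step beyond the scatter, and compound 3 lies furthest below it. Within the data shown here, the one single-point step in the set is a number 13.4 percentage points lower from compound 1 to compound 3 (beyond the scatter), where 4-methylpiperidin-1-yl replaces 4-ethylpiperazin-1-yl on an aromatic carbon; it is a modest fall, beyond the scatter.

Compound 4 `COc1cc2c(Nc3ccc4sc(C(=O)Nc5c(C)cccc5Cl)cc4c3)ncnc2cc1OCCCN1CCCCC1` differs from compound 2 in one place: piperidin-1-yl in place of 4-methylpiperazin-1-yl on a saturated chain carbon, three bonds along the chain from an oxygen on an aromatic ring. This is again an exchange of a piperazine-type ring for a piperidine-type ring, but here on a saturated chain carbon, three bonds along the chain from an oxygen on an aromatic ring, and with no further substituent on the entering ring, so the measured step from compound 1 to compound 3 is only a loose guide. Taking it as the nearest pointer, a small decrease in this assay is expected, possibly within the scatter.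

Compound 4 is therefore estimated at 43% in this assay, with a range of 28% to 58%, which corresponds to an expected step of a number 8.2 percentage points lower from compound 2 to compound 4 (within the scatter).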

Compound 4, percent growth inhibition at one concentration: 71.8%
For compound 4 the middle estimate is 28.8 percentage points below the measured one, outside the stated range (above it).
By their numbers in this assay, from the lowest: compound 3; then compound 1; then compound 2; then compound 4.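

Replacing 4-methylpiperazin-1-yl with piperidin-1-yl on a saturated chain carbon, three bonds along the chain from an oxygen on an aromatic ring, gives in this assay a rise: a number 20.6 percentage points higher from compound 2 to compound 4 (beyond the scatter). At this place, then, the ring nitrogen and methyl group lost in the change are not required for growth inhibition at the one concentration tested. A related exchange of a piperazine-type ring for a piperidine-type ring on an aromatic carbon runs the other way, a number 13.4 percentage points lower from compound 1 to compound 3 (beyond the scatter), so these two pairs show no common direction for the exchange, although they also differ in the groups carried on the rings, and no measurement available here accounts for the opposite directions.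

The compounds shown leave open whether the rise in this assay follows from the piperidine ring itself or from the change at the ring nitrogen, a question that morpholin-4-yl or pyrrolidin-1-yl on the same propyl chain would help to address. Also open, going by these compounds, is whether the rise persists with piperidin-1-yl on a shorter chain, as in 2-(piperidin-1-yl)ethyl.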